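Anilino Variants of a Propoxybenzamide Series

A few compounds are considered here, and "the series" means these few. Any claim that something is new, unique, unknown or untested is made for them only; others in the source may bear on it.

Compound 1 `CCCOc1ccc(C(=O)Nc2cccc(CC)n2)cc1` gives 29200 nM in an in vitro assay on HEK-tsA201 cells for antagonist activity at Neuronal acetylcholine receptor; alpha3/beta4 (Homo sapiens), read by fluorescence and calcium flux; a higher number here means a weaker inhibitor, a lower number a stronger inhibitor.
Compound 2 `CCCOc1ccc(C(=O)Nc2cccc(Nc3ccccc3)n2)cc1` reaches only the assay limit, > 100000 nM, in this assay.
Compound 3 `CCCOc1ccc(C(=O)Nc2cccc(Nc3ccccc3F)n2)cc1` likewise reaches only the assay limit, > 100000 nM, in this assay.

Compound 3 thus stands at the limit of > 100000 nM in this assay, at which 2 of the 3 values shown sit, with no number of its own. Compound 4 `CCCOc1ccc(C(=O)Nc2cccc(Nc3ccc(Cl)cc3)n2)cc1` differs from it by 4-chlorophenyl in place of 2-fluorophenyl on a nitrogen on an aromatic ring. The measured steps that bear on this change are an at least 3.4-fold higher number from compound 1 to compound 2 (0.53 log units; beyond the scatter) and an at least 3.4-fold higher number from compound 1 to compound 3 (0.53 log units; beyond the scatter), while a step that the two limits leave unreadable from compound 2 to compound 3. Both anilino compounds sit at the limit, so the change from one halogenated anilino group to another is expected to give a step of a number no higher from compound 3 to compound 4 (the limit leaves the size open). Compound 4 is therefore estimated at 100000 nM, between 40000 nM and 300000 nM, and most likely reported again only as a limit.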

Compound 4, half-maximal inhibitory concentration: > 100000 nM
Compound 4 was reported as a limit (the forecaster's own chance of this, stated with the estimate: 75%); the middle value sits exactly at the limit.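

With (4-chlorophenyl)amino at this position, compound 4 also gives only a limit in this assay, so a chloro group on the anilino ring yields no readable value, just as fluoro did: the limit of > 100000 nM in this assay, at which 3 of the 4 values shown sit. Putting this group in place of ethyl gives an at least 3.4-fold higher number from compound 1 to compound 4 (0.53 log units; beyond the scatter), making compound 4 the third anilino compound on the weak side of compound 1. The steps among the three anilino compounds cannot be read, as all three values are limits.

As far as these compounds go, how far beyond the limit these compounds lie stays open. So does how a propyl chain or a phenyl group without the nitrogen would read at this position in this assay.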